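The source may report more compounds than this note shows. Statements on the series, on what has been measured and on what is new or still open speak of the compounds shown alone.

Working notes on the aryl hydrazone series. Within the data shown here, compound 3 `CN(C)CCn1cnnc1-c1cc(Oc2ccc(NC(=O)N/N=C/c3ccc(Cl)cc3)cc2F)ccn1` is the lowest of the three numbers measured so far: in a functional assay on NCI-H460 cells (Homo sapiens) for cytotoxicity, read by MTT assay, with a stated time of 72 h (on this read-out higher numbers stand for weaker inhibition and lower numbers for stronger inhibition), compound 3 gives 320 nM. Compound 2 `CN(C)CCn1cnnc1-c1cc(Oc2ccc(NC(=O)N/N=C/c3ccc(F)cc3Cl)cc2F)ccn1` gives 720 nM, and compound 1 `COc1ccc(OC)c(/C=N/NC(=O)Nc2ccc(Oc3ccnc(-c4nncn4CCN(C)C)c3)c(F)c2)c1` gives 2930 nM. The steps among them are all modest: a 9.2-fold lower number from compound 1 to compound 3 (0.96 log units; beyond the scatter), a 4.1-fold lower number from compound 1 to compound 2 (0.61 log units; beyond the scatter) and a 2.3-fold lower number from compound 2 to compound 3 (0.35 log units; beyond the scatter).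

Compound 4 `CN(C)CCn1cnnc1-c1cc(Oc2ccc(NC(=O)N/N=C/c3cccc(Cl)c3Cl)cc2F)ccn1` differs from compound 3 in one place: 2,3-dichlorophenyl in place of 4-chlorophenyl on a carbon with a double bond to nitrogen. Among the measured compounds shown here, the step that bears most on this is the one from compound 2 to compound 3, where replacing 2-chloro-4-fluorophenyl with 4-chlorophenyl gave a 2.3-fold lower number from compound 2 to compound 3 (0.35 log units; beyond the scatter). For the measured compounds named here, compound 4 carries no chlorine at the position that compound 3 and compound 2 share, and adds a second chlorine instead; no measured pair tests that exact change, so the direction is taken from compound 2, which is the closer precedent. A modest rise in the number is therefore expected, a 2.0-fold higher number from compound 3 to compound 4 (0.31 log units; beyond the scatter), of roughly the size seen between compound 2 and compound 3. Compound 4 is thus expected to give about 650 nM in this assay, with a likely range from 250 nM to 1700 nM.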

Compound 4, half-maximal inhibitory concentration: 72 nM
Estimate against measurement, compound 4: 9.0-fold (0.96 log units) above; measured number below the stated range.
By their numbers in this assay, from the lowest: compound 4; then compound 3; then compound 2; then compound 1.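

In this assay, among these compounds, this position tolerates two halogens better than the earlier compounds suggested, with a 4.4-fold lower number from compound 3 to compound 4 (0.65 log units; beyond the scatter) taking the series below the 4-chlorophenyl result. The number of halogens alone does not set the outcome: 2-chloro-4-fluorophenyl and 2,3-dichlorophenyl each carry two, yet there is a 10-fold lower number from compound 2 to compound 4 (1.00 log units; beyond the scatter) on exchanging one for the other, and the span at this place widens to a 41-fold lower number from compound 1 to compound 4 (1.61 log units; beyond the scatter) against the 2,5-dimethoxyphenyl group. No available data account for these differences.

Whether both chlorines are needed remains open, as the compounds shown do not separate the 2-chlorophenyl and 3-chlorophenyl groups from 2,3-dichlorophenyl. Also open, from the compounds shown here alone, is how an aryl group bearing an amine or a carboxylic acid would behave at this place.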